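A few compounds are considered here, and "the series" means these few. Any claim that something is new, unique, unknown or untested is made for them only; others in the source may bear on it.

Of the compounds shown here, three of one family have been tested in a functional assay on A-431 cells (Homo sapiens) for cytotoxicity, read by MTT assay, with a stated time of 24 h; on this read-out lower numbers stand for stronger inhibition and higher numbers for weaker inhibition. Compound 1 `COc1ccc(/C=C\C(=O)O)c(OCc2cn(-c3ccccc3)nn2)c1CC=C(C)C` gives 21200 nM in this assay. Compound 2 `COc1ccccc1-n1cc(COc2c(/C=C\C(=O)O)ccc(OC)c2CC=C(C)C)nn1`, which carries a methoxy in place of hydrogen on an aromatic carbon, gives 32600 nM. Compound 3 `COc1ccc(/C=C\C(=O)O)c(OCc2cn(-c3cccnc3Cl)nn2)c1CC=C(C)C`, which bears a 2-chloropyridin-3-yl in place of phenyl on an aromatic nitrogen, gives 32600 nM. The differences among these three are small: a 1.5-fold higher number from compound 1 to compound 2 (0.19 log units; within the scatter), a 1.5-fold higher number from compound 1 to compound 3 (0.19 log units; within the scatter) and no change at the digits printed from compound 2 to compound 3 (within the scatter). Compound 3 therefore stands level with compound 2 at the digits given, the pair sitting at the higher end of the three numbers, with compound 1 not far away.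

Compound 4 `COc1ccc(/C=C\C(=O)O)c(OCc2cn(-c3nc4ccccc4s3)nn2)c1CC=C(C)C` changes the same place once more: 1,3-benzothiazol-2-yl in place of 2-chloropyridin-3-yl on an aromatic nitrogen. The two earlier steps at or near this aromatic nitrogen, from compound 1 to compound 3 and from compound 2 to compound 3, each stayed within the scatter, so the group on that nitrogen has not so far moved the read-out. On that basis a step of about a 1.1-fold lower number from compound 3 to compound 4 (0.04 log units; within the scatter) is expected, no larger than the scatter, in no clear direction. Compound 4 is estimated at 30000 nM, with a likely range from 12000 nM to 80000 nM.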

Compound 4, half-maximal inhibitory concentration: 20800 nM
Compound 4: the middle estimate sits 1.4-fold (0.16 log units) above what was measured; the range from low to high includes it.
By their numbers in this assay, from the lowest: compounds 4, 1, 2 and 3 (each within the scatter of the next).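

Until now every group on this aromatic nitrogen of the five-membered aromatic ring with 3 nitrogen was a single six-membered aromatic ring, whereas 1,3-benzothiazol-2-yl brings a five-membered aromatic ring with 2 hetero atoms and a six-membered aromatic ring of carbon only, yet this assay shows a 1.6-fold lower number from compound 3 to compound 4 (0.20 log units; within the scatter) and a 1.6-fold lower number from compound 2 to compound 4 (0.20 log units; within the scatter) and a 1.0-fold lower number from compound 1 to compound 4 (0.01 log units; within the scatter) for this change. The flat picture at this position therefore now extends to a group with more heavy atoms, a different ring count and sulfur in place of chlorine, and none of the four compounds can be ranked above another. No measurement at hand offers a reason for this flat picture.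

On these data alone, whether a non-aromatic group on that nitrogen, such as a cyclohexyl or a longer chain ending in an amine, would move the read-out remains open. The part played by the rest of the shared core is open as well, for instance what a methyl ester in place of the carboxylic acid would do, as all four compounds keep that part unchanged.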